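Replacing a Sulfur-Bearing Side Chain with a Carboxylic Acid

This account rests on a few compounds, and the source may have more. Where it says the series, first, only, none or still open, it means among the compounds named here.

Measured so far in a functional assay, tested at 2.5 mM; on this read-out lower numbers stand for less inhibition and higher numbers for more inhibition at the one concentration tested (going by the name of the read-out):
- compound 1 `CSCC[C@@H]1NC(=O)[C@H](CC(C)C)NC1=O` gives 79%
- compound 2 `CC(C)C[C@@H]1NC(=O)[C@H](CC(N)=O)NC1=O` gives 96%
- compound 3 `CC(C)C[C@@H]1NC(=O)[C@H](CS)NC1=O` gives 88.9%

Compound 1 holds the lowest of the three numbers in this assay. Its gap to compound 3 is within the usual scatter, so the two cannot be ordered, while its gap to compound 2 lies beyond it. The unmeasured compound 4 `CC(C)C[C@@H]1NC(=O)[C@H](CC(=O)O)NC1=O` shares the core of compound 1 and differs from it in one place: carboxy in place of (methylsulfanyl)methyl on a saturated chain carbon bound to a saturated ring carbon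

Two measured steps start from compound 1 and change the same side chain. The step of a number 17 percentage points higher from compound 1 to compound 2 (beyond the scatter) shows a modest rise; the step of a number 9.9 percentage points higher from compound 1 to compound 3 (within the scatter) stays within the scatter. Carboxy resembles carbamoyl in its count of heavy atoms and its hydrogen-bond donor and acceptor, so the step to compound 4 is expected to fall between these two results: a rise that is modest at most, possibly none beyond the scatter. The expected step is a number 11 percentage points higher from compound 1 to compound 4 (beyond the scatter). Compound 4 is therefore estimated at 90% in this assay, with a plausible range from 72% to 100%. Among the measured compounds shown here, only three compounds inform this guess, so the range is kept wide.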

Compound 4, a percentage reported as inhibition, at one concentration (the size of the read-out at that concentration, not a potency): 95%
Compound 4: the middle estimate sits 5 percentage points below what was measured; the range from low to high includes it.
By their numbers in this assay, from the lowest: compounds 1, 3, 4 and 2 (each within the scatter of the next, the first and the last beyond it).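

In this assay, carboxy in place of (methylsulfanyl)methyl on this saturated chain carbon (a number 16 percentage points higher from compound 1 to compound 4 (beyond the scatter)) makes a second group, after the carbamoyl of compound 2, whose step from compound 1 lies beyond the scatter. Hydroxy in place of amino on the carbonyl carbon (a number 1 percentage points lower from compound 2 to compound 4 (within the scatter)) and carboxy in place of sulfanyl (a number 6.1 percentage points higher from compound 3 to compound 4 (within the scatter)) both stay within the scatter, so this read-out cannot order compound 4 against compound 2 or compound 3, and swapping the amide for the acid leaves no visible mark on it. No measured evidence on these compounds speaks to what lies behind these numbers.

On these data alone, whether the result holds for a longer chain such as 2-carboxyethyl, for a methyl ester in place of the carboxy, or for an amine such as aminomethyl remains open. The read-out also gives the size of inhibition at one concentration rather than a potency, so compound 2, compound 3 and compound 4 could still differ at lower concentrations.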